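The source may report more compounds than this note shows. Statements on the series, on what has been measured and on what is new or still open speak of the compounds shown alone.

The series is followed in an assay on membranes from brain (Cavia porcellus) for binding affinity to Sigma non-opioid intracellular receptor 1 (Homo sapiens), read by radioligand binding; on this read-out higher numbers stand for weaker inhibition and lower numbers for stronger inhibition. Compound 1 `CC(C)c1ccc(NC(=N)Nc2ccc(C(C)C)cc2)cc1` gives 242 nM, compound 2 `CCc1cccc(NC(=N)Nc2cccc3ccccc23)c1` gives 54 nM, and compound 3 `CCc1cccc(NC(=N)N(C)c2cccc3ccccc23)c1` gives 1000 nM in this assay. Compound 3 therefore stands highest of the three numbers, with compound 1 nearest and compound 2 furthest away. Among the measured compounds shown here, the only single-point step among the measured compounds is the change from compound 2 to compound 3, methyl in place of hydrogen on a nitrogen on an aromatic ring, which gave a 19-fold higher number from compound 2 to compound 3 (1.27 log units; beyond the scatter).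

Compound 4 `CN(C(=N)Nc1cccc(N)c1)c1cccc2ccccc12`, not yet measured, differs from compound 3 by amino in place of ethyl on an aromatic carbon of a six-membered aromatic ring of carbon only, meta to a large group. For the measured compounds named here, no measured step concerns this kind of change, so nothing in the data bears directly on it. The step from compound 2 to compound 3 only shows that compound 3 is already weakly bound. Compound 4 is therefore expected to stay near compound 3 or shift somewhat weaker, a step of about a 2.5-fold higher number from compound 3 to compound 4 (0.40 log units; beyond the scatter), giving an estimated 2500 nM with a range from 800 nM to 8000 nM.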

Compound 4, half-maximal inhibitory concentration: 13000 nM
For compound 4 the middle estimate is 5.2-fold (0.72 log units) below the measured one; the measured number lies above the stated range.
By their numbers in this assay, from the lowest: compound 2; then compound 1; then compound 3; then compound 4.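

In this assay, this position on the aromatic ring of carbon only, meta to a large group, proves sensitive: amino in place of ethyl gives a 13-fold higher number from compound 3 to compound 4 (1.11 log units; beyond the scatter), so a compound that already had the highest number of the series still lost a large further amount. Among the compounds shown here, until now the only measured step was on the nitrogen, and this step shows that the ethyl position also affects the number, with compound 4 now the highest of the four. No available measurement accounts for this step.

A methyl, a hydroxyl or a longer chain at this place would help to show whether the step follows from losing ethyl or from gaining amino. From the compounds shown here alone, it also remains open whether amino in place of ethyl would have a similar effect on compound 2, which carries hydrogen on that nitrogen.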